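Vinyl Replaces Sulfanyl on a Silicon-Linked Phenyl Ring

The compounds below may be only part of what the source reports. "The series", "measured", "known", "first", "only" and "open" are said of these compounds alone.

Compound 1 `CCN(C/C=C/C#CC(C)(C)C)Cc1cccc(OC[Si](C)(C)c2ccccc2C(F)(F)F)c1`: 70 nM
Compound 2 `CCN(C/C=C/C#CC(C)(C)C)Cc1cccc(OC[Si](C)(C)c2ccc(C=O)cc2)c1`: 100 nM
Compound 3 `CCN(C/C=C/C#CC(C)(C)C)Cc1cccc(OC[Si](C)(C)c2ccc(S)cc2)c1`: 8000 nM

All three compounds share one core and differ only in the phenyl group attached to the silicon. In a functional assay on liver (Sus scrofa) for inhibition of squalene monooxygenase (Homo sapiens), using microsomes (on this read-out higher numbers stand for weaker inhibition and lower numbers for stronger inhibition), compound 1 gives 70 nM and compound 2 gives 100 nM, a step of a 1.4-fold higher number from compound 1 to compound 2 (0.15 log units; within the scatter). Compound 3 stands apart with the highest number of the three: the step is a 110-fold higher number from compound 1 to compound 3 (2.06 log units; beyond the scatter) and an 80-fold higher number from compound 2 to compound 3 (1.90 log units; beyond the scatter), so the sulfanyl group is joined to a large loss of inhibition.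

Compound 4 `C=Cc1ccc([Si](C)(C)COc2cccc(CN(CC)C/C=C/C#CC(C)(C)C)c2)cc1` takes the next step: vinyl in place of sulfanyl on an aromatic carbon. The step from compound 2 to compound 3 bears on it most directly, since it also exchanged the group at the same place, and it was large. Compounds 1 and 2, which both lack the sulfanyl group, sit close together. Removing the sulfanyl group is therefore expected to undo most of that loss, giving a large step down in this assay, estimated at a 53-fold lower number from compound 3 to compound 4 (1.73 log units; beyond the scatter). Compound 4 is expected to give about 150 nM, within a range from 40 nM to 600 nM.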

Compound 4, half-maximal inhibitory concentration: 70 nM
Compound 4: the middle estimate sits 2.1-fold (0.33 log units) above what was measured; measured number inside the range.
By their numbers in this assay, from the lowest: compounds 1, 4 and 2 (each within the scatter of the next); then compound 3.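

Exchanging sulfanyl for vinyl on this aromatic carbon gives a 110-fold lower number from compound 3 to compound 4 (2.06 log units; beyond the scatter) in this assay, so the large loss seen with sulfanyl is not shared by every small group at this place. Vinyl and formyl cannot be told apart here, the step being a 1.4-fold lower number from compound 2 to compound 4 (0.15 log units; within the scatter), and the comparison with the other ring pattern shows no change at the digits printed from compound 1 to compound 4 (within the scatter), so 4-vinylphenyl serves as well as 2-(trifluoromethyl)phenyl on the silicon. Among these four compounds, only the one with sulfanyl stands apart, but no measurement shown explains why.

Still open, as far as these compounds go, is whether a hydroxyl group or an amine at this place would lose as much as sulfanyl, or whether the loss is tied to sulfur, which a methylthio group could test. A longer chain, such as propyl, might or might not keep the inhibition that vinyl shows.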